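The source may report more compounds than this note shows. Statements on the series, on what has been measured and on what is new or still open speak of the compounds shown alone.

Compound 1 `Nc1scc(CN2CCN(c3cc(F)cc(F)c3)CC2)c1C(=O)c1ccc(Cl)cc1` and compound 2 `Nc1scc(CN2CCN(c3cc(Cl)ccc3Cl)CC2)c1C(=O)c1ccc(Cl)cc1` share one core and differ only in the aryl group on the ring nitrogen. In an assay on CHO cells for displacement of a labelled ligand from adenosine receptor A3 (Homo sapiens), read by scintillation counting, with a stated time of 120 min, tested at 10 uM (a lower number here means less inhibition, a higher number more inhibition at the concentration tested (going by the name of the read-out)), compound 1 gives 2% and compound 2 gives 1%. Compound 2 stands at the lower of the two numbers, but its gap to compound 1 is within the scatter, so no order between them is claimed. For the measured compounds named here, the one measured step, a number 1 percentage points lower from compound 1 to compound 2 (within the scatter), shows that exchanging the aryl group leaves the read-out essentially unchanged. Compound 3 `Nc1scc(CN2CCN(c3ccc(Cl)c(Cl)c3)CC2)c1C(=O)c1ccc(Cl)cc1` is the unmeasured member. It differs from compound 2 in 3,4-dichlorophenyl in place of 2,5-dichlorophenyl on an amine nitrogen in a ring. Going by the values given here, the step from compound 1 to compound 2 is the only one bearing on this change, and it lies within the scatter. An exchange of the same kind is therefore expected to give no step beyond the scatter in this assay, estimated as a number 2 percentage points higher from compound 2 to compound 3 (within the scatter). Compound 3 is expected to give about 3% in this assay, with a range from -8% to 15%.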

Compound 3, a percentage reported as inhibition, at one concentration (the size of the read-out at that concentration, not a potency): 3%
Compound 3: the middle estimate sits on the measured number at the digits printed, within the range that was stated.
By their numbers in this assay, from the lowest: compounds 2, 1 and 3 (each within the scatter of the next).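

Placing the 3,4-dichlorophenyl group on the amine nitrogen in the ring gives, in this assay, a number 2 percentage points higher from compound 2 to compound 3 (within the scatter) and a number 1 percentage points higher from compound 1 to compound 3 (within the scatter) as the two new steps. Compound 2 and compound 3 hold the same atoms joined differently, so rearranging the two chlorines on the phenyl ring, and not only exchanging one aryl group for another, now stands within the scatter at this position, with no order among the three compounds. No measurement at hand bears on why the read-out stays this flat.

All three groups at this position are halogen-bearing phenyl rings, so the series says nothing yet about other kinds of group there. As far as these compounds go, whether a carboxylic acid, a dimethylamino group or a pyridine ring on that nitrogen would take the read-out beyond the scatter stays open.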